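Swapping nitro for methoxy at the assay limit

The compounds below may be only part of what the source reports. "The series", "measured", "known", "first", "only" and "open" are said of these compounds alone.

In a functional assay on Bel-7402 cells (Homo sapiens) for cytotoxicity, read by MTT assay, with a stated time of 48 h (on this read-out higher numbers stand for weaker inhibition and lower numbers for stronger inhibition), compound 3 (`COc1cc(-n2c(-c3ccc([N+](=O)[O-])cc3)cn(C(C)=O)c2=O)cc(OC)c1OC`) gives > 50000 nM as a limit and not a number. Compound 2 (`COc1cc(-n2c(-c3ccccc3)cn(C(C)=O)c2=O)cc(OC)c1OC`) likewise gives > 50000 nM as a limit. For compound 1 (`COc1ccc(-c2c[nH]c(=O)n2-c2cc(OC)c(OC)c(OC)c2)cc1`) the entry reads "not determined" (no result reported) and offers no comparison. The record therefore shows the limit of > 50000 nM in this assay, at which 2 of the 3 values shown sit, and nothing firmer. Compound 4 (`COc1ccc(-c2cn(C(C)=O)c(=O)n2-c2cc(OC)c(OC)c(OC)c2)cc1`) differs from compound 3 by methoxy in place of nitro on an aromatic carbon. Going by the values given here, the one measured change on that carbon is a step that the two limits leave unreadable from compound 2 to compound 3 and it gives no size to carry over. The estimated step in this assay is an at least 1.2-fold lower number from compound 3 to compound 4 (0.09 log units; that floor lies within the scatter) and its direction stays uncertain. In this assay the estimate for compound 4 is 40000 nM with a range from 3000 nM to 100000 nM expected.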

Compound 4, half-maximal inhibitory concentration: 9500 nM
Beside the measured number, compound 4's estimate is 4.2-fold (0.62 log units) above it; low and high end bracket the measured number.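

In this assay, the 4-methoxyphenyl group gives the first readable activity at this position: an at least 5.2-fold lower number from compound 3 to compound 4 (0.72 log units; beyond the scatter). Methoxy in place of hydrogen on the same carbon gives an at least 5.2-fold lower number from compound 2 to compound 4 (0.72 log units; beyond the scatter). Both steps are only floors, because compound 2 and compound 3 each stand at a limit of the assay rather than at a number: the limit of > 50000 nM in this assay, at which 2 of the 4 values shown sit.

From the compounds shown here alone, whether an amine, a hydroxyl group or a longer chain such as ethoxy on this carbon would lower the number further stays open. Going by these compounds, the part played by the acetyl group also stays open, as compound 1, which lacks it, has no result to compare.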